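Fluoro to amino on the phenyl ring of the core

The source may report more compounds than this note shows. Statements on the series, on what has been measured and on what is new or still open speak of the compounds shown alone.

Of the compounds shown here, three on the shared core have been measured in a functional assay on HepG2 cells (Homo sapiens) for inhibition, read by MTT assay, with a stated time of 72 h; a lower number here means a stronger inhibitor, a higher number a weaker inhibitor. Compound 1 `CC(C)(C)n1cc2c(n1)C(=O)CC1(CCN(C(=O)c3cc(-c4ccccc4)nc4ccccc34)CC1)O2` gives 2110 nM. Compound 2 `Cc1ccc(-c2cc(C(=O)N3CCC4(CC3)CC(=O)c3nn(C(C)(C)C)cc3O4)c3ccccc3n2)cc1` gives 1440 nM. Compound 3 `CC(C)(C)n1cc2c(n1)C(=O)CC1(CCN(C(=O)c3cc(-c4ccc(F)cc4)nc4ccccc34)CC1)O2` gives 2930 nM. Compound 3 holds the highest of the three numbers: the step of a 1.4-fold higher number from compound 1 to compound 3 (0.14 log units; within the scatter) is within the scatter, while a 2.0-fold higher number from compound 2 to compound 3 (0.31 log units; beyond the scatter) is modest but beyond it. The step of a 1.5-fold lower number from compound 1 to compound 2 (0.17 log units; within the scatter) stays within the scatter.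

Compound 4 `CC(C)(C)n1cc2c(n1)C(=O)CC1(CCN(C(=O)c3cc(-c4ccc(N)cc4)nc4ccccc34)CC1)O2` is not yet measured. It differs from compound 3 as follows: amino in place of fluoro on an aromatic carbon. For the measured compounds named here, no measured step exchanges a fluoro for an amino. Going by the values given here, the steps that bear on it are the two that exchange groups at the same aromatic carbon, a 1.4-fold higher number from compound 1 to compound 3 (0.14 log units; within the scatter) and a 2.0-fold higher number from compound 2 to compound 3 (0.31 log units; beyond the scatter), and both are small. On that basis the step of a 1.5-fold lower number from compound 3 to compound 4 (0.17 log units; within the scatter) is expected to be small, at most around the edge of the scatter, leaning toward a lower number because compound 3 stands at 2930 nM, the highest of the three. Compound 4 is estimated at 2000 nM, with a range from 800 nM to 5000 nM; a result indistinguishable from compound 3 would be no surprise.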

Compound 4, half-maximal inhibitory concentration: 630 nM
For compound 4 the middle estimate is 3.2-fold (0.50 log units) above the measured one; the whole stated range lies above it.
By their numbers in this assay, from the lowest: compound 4; then compounds 2, 1 and 3 (each within the scatter of the next, the first and the last beyond it).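

In this assay, for the compounds shown here, the 4-aminophenyl group is the first at this position to separate from all three other groups, with each step beyond the scatter: hydrogen (a 3.3-fold lower number from compound 1 to compound 4 (0.52 log units; beyond the scatter)), methyl (a 2.3-fold lower number from compound 2 to compound 4 (0.36 log units; beyond the scatter)) and fluoro (a 4.7-fold lower number from compound 3 to compound 4 (0.67 log units; beyond the scatter)). Among the earlier compounds, the only step beyond the scatter was the modest one between methyl and fluoro (a 2.0-fold higher number from compound 2 to compound 3 (0.31 log units; beyond the scatter)), so this carbon, para to a large group, had shown little sensitivity to substitution until amino entered and compound 4 took the lowest number of the four. The exchange of fluoro for amino replaces one heavy atom with one heavy atom and adds a hydrogen-bond donor and a hydrogen-bond acceptor, but no measurement available here connects that difference to the result.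

From the compounds shown here alone, whether this shift is specific to the primary amine remains open, and a hydroxyl, methylamino, dimethylamino or acetamido group on the same carbon would test that. Also open, going by these compounds, is how an amino group at another carbon of this phenyl ring would compare with the 4-aminophenyl group.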